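The source may report more compounds than this note shows. Statements on the series, on what has been measured and on what is new or still open speak of the compounds shown alone.

Measured so far in a functional assay on MCF-10A cells (Homo sapiens) for antiproliferative activity, with a stated time of 48 h; on this read-out lower numbers stand for an effect already at smaller amounts and higher numbers for an effect only at larger amounts of compound:

Compound 1 `COc1ccc2nc(C)cc(NCc3ccncc3)c2c1`: 40900 nM
Compound 2 `COc1ccc2nc(C)cc(SCc3ccc(F)cc3)c2c1`: 41000 nM

Compound 1 stands level with compound 2, since their two numbers lie within the usual scatter of each other. Among the compounds with values here, with only these two values, the series offers no measured step between compounds that differ in one place.

Compound 3 `COc1ccc2nc(C)cc(NCC3CCCN(C)C3)c2c1` has not yet been measured. Compared with compound 1, it carries 1-methylpiperidin-3-yl in place of pyridin-4-yl on a saturated chain carbon bound to a nitrogen on an aromatic ring. Within the data shown here, no measured result shows what this exchange does in this assay, so the only guide is the level of the two known compounds, compound 1 at 40900 nM and compound 2 at 41000 nM. Neither direction is favoured on these data, and no change beyond the scatter is expected. The estimated step, a 1.2-fold lower number from compound 1 to compound 3 (0.07 log units; within the scatter), is therefore small and carries a wide margin. Compound 3 is expected at 35000 nM, with an estimated range from 10000 nM to 90000 nM.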

Compound 3, half-maximal effective concentration: 6400 nM
Compound 3: middle estimate off by 5.5-fold (0.74 log units), on the high side; the measured number lies below the stated range.
By their numbers in this assay, from the lowest: compound 3; then compounds 1 and 2 (each within the scatter of the next).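

In this assay, within the data shown here, the place on a saturated chain carbon bound to a nitrogen on an aromatic ring is now seen to respond to a change of group, which the level values of the earlier compounds could not show: 1-methylpiperidin-3-yl in place of pyridin-4-yl gives a 6.4-fold lower number from compound 1 to compound 3 (0.81 log units; beyond the scatter). The exchange replaces a six-membered aromatic ring with a six-membered non-aromatic ring, and each group has one ring hetero atom, so the computed counts of hydrogen-bond donors and acceptors and the net charge do not distinguish the two groups. No measurement at hand gives a reason for this step.

Among these compounds, the single exchange alters the aromatic character of the ring, the methyl on the ring nitrogen and the point of ring attachment together, leaving open which of these parts carries the step. Piperidin-3-yl without the methyl, 1-methylpiperidin-4-yl and pyridin-3-yl on the same chain carbon would each separate one of these parts, and the outcome for each remains open.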